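Cytotoxicity in Rat Cells: Amide for Cyano-Fluorophenyl

The source may report more compounds than this note shows. Statements on the series, on what has been measured and on what is new or still open speak of the compounds shown alone.

The study measured toxicity toward rat muscle-derived cells in an ADME assay on L6 cells (Rattus norvegicus) for cytotoxicity, read by resazurin assay, with a stated time of 72 h; a lower number here means a stronger inhibitor, a higher number a weaker inhibitor. Compound 1 `OC(c1ccc(Cl)cc1)(c1ccc(C(F)(F)F)cc1)c1cccnc1` gives 56400 nM in this assay. Compound 2 `N#Cc1ccc(C(O)(c2ccc(C(F)(F)F)cc2)c2cccnc2)c(F)c1` gives 56100 nM, and the step of a 1.0-fold lower number from compound 1 to compound 2 (0.00 log units; within the scatter) shows that the two measured compounds sit within the scatter of each other, so neither can be set above the other on these numbers. Compound 2 is thus one of a pair of near-equal values and forms the starting point for the next compound.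

Compound 3 `NC(=O)c1ccc(C(O)(c2ccc(C(F)(F)F)cc2)c2cccnc2)cc1` has not yet been measured. It differs from compound 2 as follows: 4-carbamoylphenyl in place of 4-cyano-2-fluorophenyl on a saturated chain carbon bound to two aromatic carbons and an oxygen on a saturated carbon. Among the measured compounds shown here, the only measured step at this same position, from compound 1 to compound 2, was flat, and no other step bears on the change. Nothing in the shown data points to a movement in either direction beyond the scatter, so a step of about a 1.1-fold higher number from compound 2 to compound 3 (0.03 log units; within the scatter) is expected for compound 3. On that basis compound 3 is estimated at 60000 nM in this assay, with a range from 30000 nM to 130000 nM.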

Compound 3, half-maximal inhibitory concentration: > 100000 nM
Compound 3 gave a limit, no number; the forecaster's own chance of this, stated with the estimate: 25%; middle value at least 1.6-fold (0.22 log units) from the limit.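

In this assay, among the compounds shown here, compound 3 gave a limit of the assay and not a number, the only such reading among the three compounds at this position: the limit of > 100000 nM in this assay, at which 1 of the 3 values shown sits. The step read from that limit is a floor and not a size (an at least 1.7-fold higher number from compound 2 to compound 3 (0.25 log units; that floor lies within the scatter)), and the same holds for the comparison with the chloro compound (an at least 1.7-fold higher number from compound 1 to compound 3 (0.24 log units; that floor lies within the scatter)), so neither floor shows a change beyond the scatter, though the true gaps could be wider. Where the earlier swap at this position gave two readable values within the scatter of each other, this change offers no upper bound, and it replaces the nitrile with a carbamoyl while also removing the fluorine, so the two cannot be told apart.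

The compounds shown leave open how far the number for compound 3 lies from the others, and whether the carbamoyl or the loss of the fluorine accounts for the limit. They also leave open how a carboxylic acid or an amine in place of the carbamoyl would read in this test.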